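The compounds below may be only part of what the source reports. "The series", "measured", "known", "first", "only" and "open" are said of these compounds alone.

In a functional assay on HeLa cells (Homo sapiens) for cytotoxicity, read by MTT assay, with a stated time of 72 h (on this read-out higher numbers stand for weaker inhibition and lower numbers for stronger inhibition), compound 1 (`O=C(/C=C/c1ccc([N+](=O)[O-])cc1)Nc1cc2c(Nc3ccc(F)c(Cl)c3)ncnc2cc1O[C@H]1CCOC1`) gives 27400 nM and compound 2 (`O=C(/C=C/c1ccccc1[N+](=O)[O-])Nc1cc2c(Nc3ccc(F)c(Cl)c3)ncnc2cc1O[C@H]1CCOC1`) gives 29600 nM. Among the compounds with values here, these two numbers stand level, and the only measured step is a 1.1-fold higher number from compound 1 to compound 2 (0.03 log units; within the scatter), which lies within the scatter. Compound 2 therefore holds no distinct place of its own.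

Compound 3 (`COc1cc(/C=C/C(=O)Nc2cc3c(Nc4ccc(F)c(Cl)c4)ncnc3cc2O[C@H]2CCOC2)cc(OC)c1`) carries 3,5-dimethoxyphenyl in place of 2-nitrophenyl on a double-bonded chain carbon bound to a double-bonded chain carbon. Within the data shown here, that single measured step bears on this change only indirectly, since it exchanges 4-nitrophenyl for 2-nitrophenyl and no measured compound carries 3,5-dimethoxyphenyl. With so little evidence, no step beyond the scatter is expected in this assay, and no direction can be favoured with confidence. The expected change is a 1.2-fold lower number from compound 2 to compound 3 (0.07 log units; within the scatter). For compound 3 the estimate is 25000 nM, with an expected range from 10000 nM to 60000 nM.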

Compound 3, half-maximal inhibitory concentration: 34300 nM
For compound 3 the middle estimate is 1.4-fold (0.14 log units) below the measured one; the measured number falls inside the stated range.
By their numbers in this assay, from the lowest: compounds 1, 2 and 3 (each within the scatter of the next).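

In this assay, the place on a double-bonded chain carbon bound to a double-bonded chain carbon now holds a phenyl group with no nitro substituent, and the numbers stay level: a 1.2-fold higher number from compound 2 to compound 3 (0.06 log units; within the scatter), and a 1.3-fold higher number from compound 1 to compound 3 (0.10 log units; within the scatter). Within the data shown here, the earlier pair compared only two nitrophenyl groups, whereas these three compounds show that 3,5-dimethoxyphenyl also stands level with 2-nitrophenyl and 4-nitrophenyl. No supporting measurement is available to account for this level result.

Going by these compounds, all three groups are substituted phenyl rings, so it remains open whether a phenyl ring bearing a dimethylamino group or a carboxylic acid would move the number beyond the scatter. On these data alone, it is equally open whether an unsubstituted phenyl or a longer chain at this place would do so.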